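Moving the Bromine: Compound 2 to Compound 4

The source may hold more compounds than are shown below. What is called first, only, known or untested is meant among the compounds shown, and "the series" means these compounds.

In an ADME assay on HaCaT cells (Homo sapiens) for cytotoxicity, read by MTT assay, with a stated time of 72 h (a higher number here means a weaker inhibitor, a lower number a stronger inhibitor), compound 1 `COc1ccc(Nc2nnnn2-c2ccccc2Cl)cc1` gives 100000 nM, compound 2 `COc1ccc(Nc2nnnn2-c2cccc(Br)c2)cc1` gives 107000 nM, and compound 3 `COc1ccc(-n2nnnc2Nc2cccc(Br)c2)cc1` gives 138000 nM. Compound 2 therefore stands among the other two compounds, within the scatter of each, and these numbers set no order among the three.

Compound 4 `COc1ccc(Nc2nnnn2-c2ccc(Br)cc2)cc1` keeps the atoms of compound 2 but joins them differently, with 4-bromophenyl in place of 3-bromophenyl on an aromatic nitrogen. For the measured compounds named here, no measured pair shows this exact change. Going by the values given here, the closest evidence is the one measured step at the same place, where 3-bromophenyl replaces 2-chlorophenyl: a 1.1-fold higher number from compound 1 to compound 2 (0.03 log units; within the scatter).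

Because a 1.1-fold higher number from compound 1 to compound 2 (0.03 log units; within the scatter) stays within the scatter, that single step gives no reason to expect a real shift or to favour either direction. The step expected in this assay is a 1.0-fold higher number from compound 2 to compound 4 (0.01 log units; within the scatter), which means no expected change beyond the scatter. Compound 4 is estimated at 110000 nM, with an expected range from 60000 nM to 180000 nM.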

Compound 4, half-maximal inhibitory concentration: 103000 nM
For compound 4 the middle estimate is 1.1-fold (0.03 log units) above the measured one, and the stated range covers the measured number.
By their numbers in this assay, from the lowest: compounds 1, 4, 2 and 3 (each within the scatter of the next).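

Compound 2 and compound 4 differ only in where the bromine sits on the phenyl group, and in this assay this exchange of 3-bromophenyl for 4-bromophenyl gives a 1.0-fold lower number from compound 2 to compound 4 (0.02 log units; within the scatter), so the assay does not tell the two placements apart. Replacing the 2-chlorophenyl group of compound 1 with the 4-bromophenyl group gives a 1.0-fold higher number from compound 1 to compound 4 (0.01 log units; within the scatter), so that pair also shows no difference, and the earlier single step at this nitrogen now has two companions, all within the scatter. Nothing measured here accounts for this absence of a difference, and no supporting data bear on it.

The three groups compared at this position are all phenyl rings carrying one halogen, so they leave open whether anything of another kind there, such as an amine or a carboxylic acid on the phenyl ring, would give a step beyond the scatter. They also leave open whether a longer chain set between the aromatic nitrogen and the phenyl ring would change the number in this cell assay.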